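This account rests on a few compounds, and the source may have more. Where it says the series, first, only, none or still open, it means among the compounds named here.

Going by the values given here, compound 1 `O=C(O)Cc1sc(C(c2ccc(F)cc2)c2ccc(F)cc2)nc1-c1ccco1` carries a furan-2-yl group on the shared core and is the only compound here with a number rather than a limit: in an in vitro functional assay on HEK285-7 cells for antagonist activity at prostaglandin D2 receptor 2 (Homo sapiens), read by BRET and beta-arrestin recruitment (a lower number here means a stronger inhibitor, a higher number a weaker inhibitor), compound 1 gives 140 nM. Compound 2 `O=C(O)Cc1sc(C(c2ccccc2)c2ccccc2)nc1-c1ccc(C(F)(F)F)cc1` reaches only a limit of this assay, > 100000 nM. Compound 3 `COc1ccc(OC)c(-c2nc(C(c3ccccc3)c3ccccc3)sc2CC(=O)O)c1` likewise reaches only the limit > 100000 nM. The step that the two limits leave unreadable from compound 2 to compound 3 therefore cannot be read because both ends sit at the limit of > 100000 nM in this assay, at which 2 of the 3 values shown sit. Compound 4 `NS(=O)(=O)c1ccc(-c2nc(C(c3ccc(F)cc3)c3ccc(F)cc3)sc2CC(=O)O)cc1` differs from compound 1 by 4-sulfamoylphenyl in place of furan-2-yl on an aromatic carbon. Among the compounds with values here, no measured step tests this exchange, and compounds 2 and 3 also lack the fluorines of compound 1, so their limits give no clean guide. Compound 4 is therefore estimated at 1000 nM, within 100 nM to 30000 nM, a weakening expected as a 7.1-fold higher number from compound 1 to compound 4 (0.85 log units; beyond the scatter).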

Compound 4, half-maximal inhibitory concentration: > 100000 nM
Compound 4 gave a limit, no number; the forecaster's own chance of this, stated with the estimate: 25%; middle value at least 100-fold (2.00 log units) from the limit.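

Putting 4-sulfamoylphenyl in place of furan-2-yl, on the aromatic carbon next to the ring nitrogen, gives an at least 710-fold higher number from compound 1 to compound 4 (2.85 log units; beyond the scatter) in this assay. Going by these compounds alone, this is the first readable step at this position, and both fluorines stay in place across it, so this one exchange alone carries the whole loss. Compound 4 now joins the others that give only a limit: the limit of > 100000 nM in this assay, at which 3 of the 4 values shown sit.

Going by these compounds, whether the loss goes with the six-membered ring or with the sulfamoyl group stays open. A plain phenyl group at this position, on the core of compound 1, would separate the two.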